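Chain extension on the amino substituent of compound 2

A few compounds are considered here, and "the series" means these few. Any claim that something is new, unique, unknown or untested is made for them only; others in the source may bear on it.

Measured compounds:
compound 1, `COc1ccc(Cn2c(O)nc3c(N)ncnc32)cc1`, 10 uM in a functional assay (spleen, spleen) for activation, with Mus musculus as the target; a higher number here means that more compound is needed for the effect, a lower number that less compound is needed
compound 2, `CCNc1nc(N)c2nc(O)n(Cc3ccccc3)c2n1`, 1 uM
compound 3, `Nc1ncnc2c1nc(O)n2Cc1ccc(F)cc1`, 10 uM

Compound 2 has the lowest number of the three; compound 1 and compound 3 each sit at a markedly higher number. Going by the values given here, the only measured single-point step, no change at the digits printed from compound 1 to compound 3 (within the scatter), concerns the ring on the benzyl arm and is unrelated to the change studied here. Compound 4, `CCCCNc1nc(N)c2nc(O)n(Cc3ccccc3)c2n1`, differs from compound 2 by ethyl in place of hydrogen on a saturated chain carbon, two bonds along the chain from a nitrogen on an aromatic ring, that is, ethylamino to butylamino. Among the compounds with values here, no measured step bears on this change, so the expectation rests on compound 2 alone. Compound 4 is expected to stay near compound 2, with no change at the digits printed from compound 2 to compound 4 (within the scatter), and is estimated at 1 uM, in the range 0.3 uM to 3 uM.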

Compound 4, minimum effective concentration: 1 uM
Compound 4: the middle estimate sits on the measured number at the digits printed, within the range that was stated.
By their numbers in this assay, from the lowest: compounds 2 and 4 (each within the scatter of the next); then compounds 1 and 3 (each within the scatter of the next).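

In this assay there is no change at the digits printed from compound 2 to compound 4 (within the scatter). Going by these compounds alone, this is the first measured change on the amino substituent itself, and it shows that ethylamino and butylamino cannot be told apart in this read-out, so this part of the molecule accepts ethyl in place of hydrogen on a saturated chain carbon. No measurement offers an explanation for this result. On these data alone, whether the same holds for a longer chain such as hexylamino, or for a chain ending in an amine or a carboxylic acid, remains open.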